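Aryl replacement at the fused-ring carbon of compound 3

The source may hold more compounds than are shown below. What is called first, only, known or untested is meant among the compounds shown, and "the series" means these compounds.

Compound 3 `C=C(Br)C(=O)Nc1cccc(-c2cn3nc(-c4ccc(OC)c(OC)c4)sc3n2)c1` stands lowest of the three numbers measured in a functional assay on L1210 cells (Mus musculus) for inhibition, read by cell counting, with a stated time of 2 days; a higher number here means a weaker inhibitor, a lower number a stronger inhibitor: compound 3 gives 42 nM, while compound 1 `C=C(Br)C(=O)Nc1cccc(-c2cn3nc(-c4ccc(CC)cc4)sc3n2)c1` gives 2200 nM and compound 2 `C=C(Br)C(=O)Nc1cccc(-c2cn3nc(Cc4ccc(Cl)cc4)sc3n2)c1` gives 2300 nM. The two steps into compound 3 are large: a 52-fold lower number from compound 1 to compound 3 (1.72 log units; beyond the scatter) and a 55-fold lower number from compound 2 to compound 3 (1.74 log units; beyond the scatter). The step of a 1.0-fold higher number from compound 1 to compound 2 (0.02 log units; within the scatter) is within the scatter.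

Compound 4 `C=C(Br)C(=O)Nc1cccc(-c2cn3nc(-c4cccs4)sc3n2)c1` removes the group that marks compound 3 out: thiophen-2-yl in place of 3,4-dimethoxyphenyl on an aromatic carbon. Within the data shown here, the steps that bear on this are the two into compound 3, both large and both in the lowering direction; no measured pair carries a thiophen-2-yl, so the new group itself is untested. Because of a 52-fold lower number from compound 1 to compound 3 (1.72 log units; beyond the scatter) and a 55-fold lower number from compound 2 to compound 3 (1.74 log units; beyond the scatter), taking away the 3,4-dimethoxyphenyl from compound 3 is expected to raise the number in this assay by a sizeable step, though likely not the full way back to compound 1 or compound 2 given the different shape of the entering group. The expected step is a 14-fold higher number from compound 3 to compound 4 (1.15 log units; beyond the scatter). Compound 4 is estimated at 600 nM, with a range from 150 nM to 3000 nM.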

Compound 4, half-maximal inhibitory concentration: 170 nM
For compound 4 the middle estimate is 3.5-fold (0.55 log units) above the measured one; measured number inside the range.
By their numbers in this assay, from the lowest: compound 3; then compound 4; then compounds 1 and 2 (each within the scatter of the next).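

In this assay, among these compounds, the 3,4-dimethoxyphenyl is not the only group at this aromatic carbon that gives a low number: with thiophen-2-yl there is only a modest loss, a 4.0-fold higher number from compound 3 to compound 4 (0.61 log units; beyond the scatter), while a 13-fold lower number from compound 1 to compound 4 (1.11 log units; beyond the scatter) and a 14-fold lower number from compound 2 to compound 4 (1.13 log units; beyond the scatter) are both large steps. A low number at this position therefore does not require the 2 oxygen atoms of the 3,4-dimethoxyphenyl, although compound 3 remains beyond the scatter from compound 4 in the lowering direction. No measurement at hand bears on the reason for these steps.

Still open, on these data alone, is whether a single methoxy group on the phenyl ring would bring the number close to that of compound 3. Also open, as far as these compounds go, is how a furan-2-yl, or a phenyl ring carrying an amine or a carboxylic acid, would read at this carbon.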